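The source may hold more compounds than are shown below. What is called first, only, known or untested is meant among the compounds shown, and "the series" means these compounds.

Measured so far in a functional assay on HeLa cells (Homo sapiens) for inhibition, read by CCK-8 assay, with a stated time of 48 h; a lower number here means a stronger inhibitor, a higher number a weaker inhibitor:
compound 1 `COc1cc(-c2ccnc3cc(-c4ccc(F)cc4)nn23)cc(OC)c1OC` gives 5840 nM
compound 2 `COc1cc(-c2ccnc3cc(-c4ccc(C(F)(F)F)cc4)nn23)cc(OC)c1OC` gives 1840 nM
compound 3 `COc1cc(-c2ccnc3cc(-c4cn(C)c5ccccc45)nn23)cc(OC)c1OC` gives 399 nM

Compound 1 stands highest of the three numbers in this assay; its nearest neighbour is compound 2, with a 3.2-fold lower number from compound 1 to compound 2 (0.50 log units; beyond the scatter), and the furthest is compound 3, with a 15-fold lower number from compound 1 to compound 3 (1.17 log units; beyond the scatter). Between the other two, a 4.6-fold lower number from compound 2 to compound 3 (0.66 log units; beyond the scatter).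

Compound 4 `COc1ccc(-c2cc3nccc(-c4cc(OC)c(OC)c(OC)c4)n3n2)cc1F` is not yet measured in this assay. From compound 1 it differs at one place: 3-fluoro-4-methoxyphenyl in place of 4-fluorophenyl on an aromatic carbon.

The measured steps all vary the same aromatic substituent of the shared core. The closest comparison is a 3.2-fold lower number from compound 1 to compound 2 (0.50 log units; beyond the scatter), which also keeps a single six-membered carbon ring and changes only what sits on it; a 15-fold lower number from compound 1 to compound 3 (1.17 log units; beyond the scatter) replaces the ring altogether and is less informative here. Among the measured compounds shown here, no measured step adds a methoxy on this ring, so the direction of the step from compound 1 to compound 4 is uncertain. A modest lowering is expected, near the size of a 3.2-fold lower number from compound 1 to compound 2 (0.50 log units; beyond the scatter) or smaller, and a result within the scatter cannot be excluded.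

Compound 4 is estimated to give 3200 nM in this assay, with a range from 1300 nM to 8000 nM. This estimate corresponds to an expected 1.8-fold lower number from compound 1 to compound 4 (0.26 log units; within the scatter).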

Compound 4, half-maximal inhibitory concentration: 236 nM
Estimate against measurement, compound 4: 14-fold (1.13 log units) above, outside the stated range (below it).
By their numbers in this assay, from the lowest: compounds 4 and 3 (each within the scatter of the next); then compound 2; then compound 1.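

Working notes on the aryl position of the series, in this assay: with a single six-membered carbon ring kept on the aromatic carbon of the five-membered ring, swapping 4-fluorophenyl for 3-fluoro-4-methoxyphenyl gives a 25-fold lower number from compound 1 to compound 4 (1.39 log units; beyond the scatter), so a large change at this position does not require replacing that ring. The fused 1-methyl-1H-indol-3-yl group of compound 3 is therefore not needed to reach this level, and a 1.7-fold lower number from compound 3 to compound 4 (0.23 log units; within the scatter) leaves the two compounds unseparated. Substitution on the ring also matters well beyond the earlier fluoro to trifluoromethyl change, with a 7.8-fold lower number from compound 2 to compound 4 (0.89 log units; beyond the scatter).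

No measured data here account for the size of this change. On these data alone, it remains open how much of it belongs to the methoxy and how much to the added fluoro, and whether 4-methoxyphenyl alone, or a dimethylamino group or carboxylic acid on this ring, would give a similar number.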